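Three thioethers at the assay limit and a fourth expected there

This account rests on a few compounds, and the source may have more. Where it says the series, first, only, none or still open, it means among the compounds named here.

Compound 1, `Cc1ccc(C(=O)CSc2nnc(C)n2N2C(=O)c3ccccc3C2=O)cc1`: in a functional assay on MKN-45 cells (Homo sapiens) for cytotoxicity, read by MTT assay, with a stated time of 48 h (on this read-out lower numbers stand for stronger inhibition and higher numbers for weaker inhibition), compound 1 gives > 200000 nM, a limit of the assay rather than a number.
Compound 2, `C#CCSc1nnc(C)n1N1C(=O)c2ccccc2C1=O`: in this assay compound 2 gives > 200000 nM, again only a limit.
Compound 3, `CCCc1nnc(SCC(=O)c2ccc(C)cc2)n1N1C(=O)c2ccccc2C1=O`: in this assay compound 3 gives > 200000 nM, also a limit.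

Compound 1 and compound 2 differ by ethynyl in place of (4-methylphenyl)carbonyl on a saturated chain carbon bound to a sulfur. The step that the two limits leave unreadable from compound 1 to compound 2, since both values are limits. The cores of compound 1 and compound 3 differ by ethyl in place of hydrogen on a saturated chain carbon bound to an aromatic carbon.

Compound 4, `C#CCSc1nnc(CCC)n1N1C(=O)c2ccccc2C1=O`, has not yet been measured in this assay. It differs from compound 3 by ethynyl in place of (4-methylphenyl)carbonyl on a saturated chain carbon bound to a sulfur; the place is the same in words, so this is the same change as that from compound 1 to compound 2.

For compound 4 in this assay a step of a number no higher from compound 3 to compound 4 (the limit leaves the size open) is expected, because the limit of > 200000 nM in this assay, at which 3 of the 3 values shown sit, leaves no readable movement on either side of the change. Compound 4 is estimated at 200000 nM, most likely reported as a limit, with an expected span from 60000 nM to 600000 nM.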

Compound 4, half-maximal inhibitory concentration: > 200000 nM
Compound 4 gave a limit, no number; the forecaster's own chance of this, stated with the estimate: 80%; the middle value sits exactly at the limit.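

No step can be read from compound 3 to compound 4 or from compound 2 to compound 4, because the values give no number to compare: the limit of > 200000 nM in this assay, at which 4 of the 4 values shown sit.

The compounds shown leave open whether ethynyl in place of (4-methylphenyl)carbonyl, or ethyl in place of hydrogen, changes the result in this assay at all, and how strongly any of the four compounds acts there.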